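This account rests on a few compounds, and the source may have more. Where it says the series, first, only, none or still open, it means among the compounds named here.

Of the compounds shown here, three built on one shared core have been tested in a functional assay on MIA PaCa-2 cells (Homo sapiens) for inhibition, read by MTT assay, with a stated time of 3 days; on this read-out lower numbers stand for stronger inhibition and higher numbers for weaker inhibition. Compound 1 `CCOC(=O)[C@@H]1C[C@H](O)CN(S(=O)(=O)c2ccc(S(=O)(=O)N(CC)CC)cc2)C1` gives > 10000 nM, which is a limit of the assay rather than a number. Compound 2 `CCOC(=O)[C@@H]1CCCN(S(=O)(=O)c2ccc(S(=O)(=O)N(CC)C(C)C)cc2)C1` likewise gives > 10000 nM, again a limit. Compound 3 `CCOC(=O)[C@@H]1CCCN(S(=O)(=O)c2ccc(S(=N)(=O)N(CC)CC)cc2)C1` also gives > 10000 nM, once more a limit. Compound 3 therefore stands exactly where the whole set stands, at the limit of > 10000 nM in this assay, at which 3 of the 3 values shown sit. Within the data shown here, the only change among the measured compounds that touches a single place, a step that the two limits leave unreadable from compound 2 to compound 3, cannot be read, because both of its ends are limits.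

Compound 4 `CCOC(=O)[C@@H]1CCCN(S(=O)(=O)c2ccc(C(=O)N(CC)CC)cc2)C1` is the next compound, not yet measured. It differs from compound 3 in one place: a group of 7 heavy atoms (5 carbon, 1 nitrogen, 1 oxygen; no ring) in place of a group of 8 heavy atoms (4 carbon, 2 nitrogen, 1 oxygen, 1 sulfur; no ring), on an aromatic carbon. Among the measured compounds shown here, no measured step bears on this change in a readable way, since the one step available gave only limits on both sides. With every value shown sitting at the limit, nothing supports an expectation of a step in this assay beyond the scatter in either direction. Compound 4 is therefore expected to give about 15000 nM, with a range from 6000 nM to 40000 nM, and most likely to be reported again only as a limit. The expected step behind this estimate is a step that the limit leaves unreadable from compound 3 to compound 4, that is, no readable change.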

Compound 4, half-maximal inhibitory concentration: > 10000 nM
Compound 4 was reported as a limit; the forecaster's own chance of this, stated with the estimate: 80%; the middle value lies beyond the limit too.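

No step can be read from compound 3 to compound 4 or from compound 2 to compound 4, since each of these compounds is reported only as a limit, not as a number: the limit of > 10000 nM in this assay, at which 4 of the 4 values shown sit. The compounds shown leave open whether any change to the shared core brings a measurable value in this assay and how large such a step would be.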